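The source may hold more compounds than are shown below. What is called first, only, known or untested is meant among the compounds shown, and "the series" means these compounds.

Working notes on the series, all read in a functional assay on HeLa cells (Homo sapiens) for inhibition, read by CCK-8 assay, with a stated time of 72 h, tested at 2 uM; on this read-out lower numbers stand for less inhibition of growth and higher numbers for more inhibition of growth at the one concentration tested. Of the compounds shown here, two have numbers so far. Compound 1 `COc1ccc(SCc2ccc(/C=C/C(=O)Nc3ccccc3N)cc2)cc1OC` gives 10.1%. Compound 2 `COc1ccc(SCc2ccc(C(=O)Nc3ccccc3N)cc2)cc1` gives 35%, the higher of the two numbers, and the gap to compound 1 lies beyond the usual scatter.

Next in line is compound 3 `CCc1ccc(SCc2ccc(C(=O)Nc3ccccc3N)cc2)cc1`, which has no number yet. It differs from compound 2 at a single place: ethyl in place of methoxy on an aromatic carbon. In words, this is ethyl in place of methoxy on an aromatic carbon, para to a large group, or 4-methoxyphenyl to 4-ethylphenyl when cut one bond further out.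

Among the compounds with values here, no measured pair shows what a change at this place does, so the expectation stays close to compound 2 at 35%, with a wide margin. The expected step is a number 5 percentage points lower from compound 2 to compound 3 (within the scatter), small, downward and not beyond the scatter. In this assay the estimated value for compound 3 is 30%, with an expected range of 14% to 47%.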

Compound 3, percent growth inhibition at one concentration: 30.8%
Estimate against measurement, compound 3: 0.8 percentage points below; low and high end bracket the measured number.
By their numbers in this assay, from the lowest: compound 1; then compounds 3 and 2 (each within the scatter of the next).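

Within the data shown here, this is the first measured pair at this position. In this assay, ethyl in place of methoxy on an aromatic carbon, para to a large group, gives a number 4.2 percentage points lower from compound 2 to compound 3 (within the scatter) and so does not separate 4-methoxyphenyl from 4-ethylphenyl, although the change takes away the oxygen and the one hydrogen-bond acceptor of the methoxy group. At this one concentration, the read-out therefore shows no dependence on that oxygen or acceptor at this position, and no measurement is available that explains the size of the step.

The compounds shown leave open whether a group of a different kind at this position, such as an amine, a carboxylic acid or a longer chain, would give a step beyond the scatter. On these data alone, compound 1 differs from compound 2 and compound 3 in more than one place, so it gives no reading of this position, and the behaviour of the pair at other concentrations also remains open.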